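Working notes: a chloro step in the cytotoxicity series

This account rests on a few compounds, and the source may have more. Where it says the series, first, only, none or still open, it means among the compounds named here.

Measured so far:
Compound 1 `N#Cc1ccc2c(c1)/C(=N\OCc1ccccc1)C(c1c[nH]c3ccc(C#N)cc13)=N2`; in an ADME assay on HUVEC cells (Homo sapiens) for cytotoxicity, read by MTT assay, with a stated time of 2 days (on this read-out lower numbers stand for stronger inhibition and higher numbers for weaker inhibition), compound 1 gives > 100000 nM, which is a limit of the assay and not a number.
Compound 2 `Fc1ccc(CO/N=C2/C(c3c[nH]c4ccccc34)=Nc3ccccc32)cc1`; in this assay compound 2 gives > 100000 nM, again a limit of the assay.

Compound 2 stands at the limit, as do both values shown (the limit of > 100000 nM in this assay, at which 2 of the 2 values shown sit). Among the compounds with values here, no step between measured compounds is available, so no direction is read from the data. Compound 3 `Fc1ccc(CO/N=C2/C(c3c[nH]c4ccccc34)=Nc3ccccc32)c(Cl)c1` differs from compound 2 by chloro in place of hydrogen on an aromatic carbon. The step from compound 2 to compound 3 is expected to be a number no higher from compound 2 to compound 3 (the limit leaves the size open), none beyond the scatter. Compound 3 is estimated at 100000 nM, within 30000 nM to 300000 nM.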

Compound 3, half-maximal inhibitory concentration: > 100000 nM
Compound 3: a limit, no number; the forecaster's own chance of this, stated with the estimate: 75%; the middle value lies on the limit itself.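

In this assay no step can be read between compound 2 and compound 3, as both values are limits and not numbers: the limit of > 100000 nM in this assay, at which 3 of the 3 values shown sit.

What chloro in place of hydrogen does to cytotoxicity stays open: none of the compounds shown gives a number.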